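Chloro for fluoro on the triazole-linked phenyl ring

The compounds below may be only part of what the source reports. "The series", "measured", "known", "first", "only" and "open" are said of these compounds alone.

Compound 3 `O=c1[nH]cc(S(=O)(=O)Nc2ccccc2-c2cn(-c3cccc(F)c3)nn2)c(=O)[nH]1` gives 8130 nM in a functional assay on A549 cells (Homo sapiens) for antiproliferative activity, read by MTT assay, with a stated time of 24 h (on this read-out lower numbers stand for stronger inhibition and higher numbers for weaker inhibition), the highest number among the three measured compounds. Compound 1 `O=c1[nH]cc(S(=O)(=O)Nc2ccccc2-c2cn(-c3ccccc3)nn2)c(=O)[nH]1` gives 6790 nM in this assay, and the step of a 1.2-fold higher number from compound 1 to compound 3 (0.08 log units; within the scatter) lies within the scatter. Compound 2 `Cc1cccc(-n2cc(-c3ccccc3NS(=O)(=O)c3c[nH]c(=O)[nH]c3=O)nn2)c1` gives 1870 nM in this assay; the step of a 4.3-fold higher number from compound 2 to compound 3 (0.64 log units; beyond the scatter) stands beyond the scatter, as does the step of a 3.6-fold lower number from compound 1 to compound 2 (0.56 log units; beyond the scatter).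

The change to compound 4 `O=c1[nH]cc(S(=O)(=O)Nc2ccccc2-c2cn(-c3ccc(Cl)cc3)nn2)c(=O)[nH]1` is 4-chlorophenyl in place of 3-fluorophenyl on an aromatic nitrogen. Among the measured compounds shown here, none of the measured steps places a chlorine on that ring, and none places any group where the 4-chlorophenyl group carries its chlorine, so the measured steps bear on it only indirectly. A fluorine on the phenyl ring gave a 1.2-fold higher number from compound 1 to compound 3 (0.08 log units; within the scatter), a change inside the scatter, while a methyl gave a 3.6-fold lower number from compound 1 to compound 2 (0.56 log units; beyond the scatter), a modest move to a lower number. A chlorine in place of the fluorine is therefore expected to leave this assay roughly where compound 3 stands, or to bring a modest lower number, with an uncertainty wider than either measured step. Compound 4 is estimated at 5000 nM, within 1500 nM to 16000 nM, which corresponds to an expected step of a 1.6-fold lower number from compound 3 to compound 4 (0.21 log units; within the scatter).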

Compound 4, half-maximal inhibitory concentration: 1180 nM
For compound 4 the middle estimate is 4.2-fold (0.63 log units) above the measured one; the whole stated range lies above it.
By their numbers in this assay, from the lowest: compounds 4 and 2 (each within the scatter of the next); then compounds 1 and 3 (each within the scatter of the next).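

The 4-chlorophenyl group brings the number in this assay to the level of the 3-methylphenyl group: against the unsubstituted phenyl the change gives a 5.8-fold lower number from compound 1 to compound 4 (0.76 log units; beyond the scatter) and set against compound 2 it gives a 1.6-fold lower number from compound 2 to compound 4 (0.20 log units; within the scatter) so this place on the aromatic nitrogen tolerates more than one substituted phenyl at that level. The exchange of 3-fluorophenyl for 4-chlorophenyl gives a 6.9-fold lower number from compound 3 to compound 4 (0.84 log units; beyond the scatter) which shows that a halogen on this ring need not leave the number unmoved, as the fluorine of compound 3 alone might have suggested, although this step alters both the halogen and its place on the ring. Nothing given here accounts for this difference.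

The compounds shown do not separate the identity of the halogen from its place on the ring, a question that 3-chlorophenyl and 4-fluorophenyl would address directly. As far as these compounds go, it also remains open whether 4-methylphenyl, 4-methoxyphenyl or 4-aminophenyl at the same place would give numbers like those of compound 2 and compound 4 or would depart from them.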